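A Bromo Group Added at the Limit of the Assay

A few compounds are considered here, and "the series" means these few. Any claim that something is new, unique, unknown or untested is made for them only; others in the source may bear on it.

Compound 1 `O=[N+]([O-])c1ccc(/N=N/N2CCCC2)cc1` and compound 2 `c1ccc(/N=N/N2CCCC2)cc1` were both tested in an ADME assay on MDBK cells (Bos taurus) for cytotoxicity, read by MTT assay, with a stated time of 96 h; a lower number here means that less compound is tolerated, a higher number that more compound is tolerated. In this assay compound 1 gives > 100000 nM, which is a limit and not a number. Compound 2 gives > 100000 nM, and this too is only a limit. For compound 1 and compound 2 the standing is thus (the limit of > 100000 nM in this assay, at which 2 of the 2 values shown sit). Compound 3 `Brc1ccc(/N=N/N2CCCC2)cc1` now follows from compound 2 by one change, (bromo in place of hydrogen on an aromatic carbon), with bromo in place of hydrogen on an aromatic carbon. Among the measured compounds shown here, the only measured step bearing on this, with hydrogen in place of nitro on an aromatic carbon, is a step that the two limits leave unreadable from compound 1 to compound 2, and on that evidence no step beyond the scatter, in either direction, is expected for the bromo group in this assay. The estimated change is a number no higher from compound 2 to compound 3 (the limit leaves the size open). Compound 3 is expected at 100000 nM, with an estimated range from 45000 nM to 150000 nM. It may well be reported as a limit again.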

Compound 3, half-maximal cytotoxic concentration: > 100000 nM
Compound 3 ended at the assay's limit; the forecaster's own chance of this, stated with the estimate: 70%; the middle value sits exactly at the limit.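

No step can be read between compound 3 and either compound 1 or compound 2 in this assay, as all three stand only at a limit and not at a number: the limit of > 100000 nM in this assay, at which 3 of the 3 values shown sit. The compounds shown leave open how far past that limit each one lies, and whether nitro, hydrogen and bromo differ at all here.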